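From 2-hydroxyethyl to ethyl: compound 1 to compound 4

This account rests on a few compounds, and the source may have more. Where it says the series, first, only, none or still open, it means among the compounds named here.

- compound 1 `Cc1cc(Nc2ccc(C(F)(F)F)cc2)n2nc(CCO)nc2n1` gives < 5 mL.min-1.g-1
- compound 2 `CCc1nc2nc(C)cc(Nc3cccc(Cl)c3)n2n1` gives 78.3 mL.min-1.g-1
- compound 3 `COCc1nc2nc(C)cc(Nc3ccc(S(F)(F)(F)(F)F)cc3)n2n1` gives 5.6 mL.min-1.g-1

In an in vitro ADME assay on microsomes from liver (Homo sapiens) for metabolic stability (a lower number here means slower removal, a higher number faster removal of the compound), compound 1 gives < 5 mL.min-1.g-1 as a limit of the assay, not a number. Of the three compounds, only compound 1 sits at this limit.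

Compound 4 `CCc1nc2nc(C)cc(Nc3ccc(C(F)(F)F)cc3)n2n1` is compound 1 with 2-hydroxyethyl changed to ethyl (hydrogen in place of hydroxy on a saturated chain carbon, two bonds along the chain from an aromatic carbon), that is, hydrogen in place of hydroxy on a saturated chain carbon, two bonds along the chain from an aromatic carbon. Among the measured compounds shown here, no measured pair isolates this change. Compound 2 also carries ethyl, with a different aromatic group, and gives 78.3 mL.min-1.g-1 as the main ground for expecting a rise. Compound 3 also lacks hydroxy and gives 5.6 mL.min-1.g-1 and so goes against that reading, which keeps the expectation moderate. The estimated step is an at least 4.0-fold higher number from compound 1 to compound 4 (0.60 log units; beyond the scatter) and it is expected to be upward, beyond the scatter in this assay for this kind of measurement. For compound 4 the expected value is 20 mL.min-1.g-1 (estimated range 7 mL.min-1.g-1 to 60 mL.min-1.g-1).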

Compound 4, intrinsic clearance in microsomes: < 5 mL.min-1.g-1
Compound 4: only a limit was reported; the forecaster's own chance of this, stated with the estimate: 8%; at least 4.0-fold (0.60 log units) between middle value and limit.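

Compound 1 and compound 4 both stand at a limit of this assay, not at a number, so no step can be read between them: the limit of < 5 mL.min-1.g-1 in this assay, at which 2 of the 4 values shown sit.

The compounds shown leave open how far each lies past that limit, and whether changing 2-hydroxyethyl to ethyl shifts the read-out at all.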